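From 2-fluorophenyl to 3,4-dimethylphenyl on the shared core

The source may hold more compounds than are shown below. What is called first, only, known or untested is meant among the compounds shown, and "the series" means these compounds.

Of the compounds shown here, three sharing one core have been tested in a functional assay on ECa-109 cells for inhibition, with ECa-109 cell line (Homo sapiens) as the target, read by sulforhodamine B assay; a lower number here means a stronger inhibitor, a higher number a weaker inhibitor. Going by the values given here, compound 2 `O=C1C(Nc2ccccc2F)=CC(=O)c2c1nc1n2[C@H]2OC[C@@H](O)[C@H]2OC1` gives 2660 nM, the only actual number among them. Compound 3 `O=C1C=C(N2CCC2)C(=O)c2c1nc1n2[C@H]2OC[C@@H](O)[C@H]2OC1` is reported only as a limit, > 16000 nM. Compound 4 `Cc1ccc(NC2=CC(=O)c3c(nc4n3[C@H]3OC[C@@H](O)[C@H]3OC4)C2=O)cc1C` is still unmeasured and carries 3,4-dimethylphenyl in place of 2-fluorophenyl on an amine nitrogen. Among the compounds with values here, no step between measured compounds is available to size this change. Compound 1 `CCCc1ccc(NC2=CC(=O)c3nc4n(c3C2=O)[C@H]2OC[C@@H](O)[C@H]2OC4)cc1`, which also has an alkyl-bearing phenyl, is likewise known only as a limit, > 4000 nM, and this leads to the expectation of a modest weakening. In this assay the expected step is a 1.7-fold higher number from compound 2 to compound 4 (0.23 log units; within the scatter). Compound 4 is estimated at 4500 nM, with an expected range of 1500 nM to 13000 nM.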

Compound 4, half-maximal inhibitory concentration: 4090 nM
For compound 4 the middle estimate is 1.1-fold (0.04 log units) above the measured one, and the stated range covers the measured number.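

Going by these compounds alone, replacing 2-fluorophenyl with 3,4-dimethylphenyl on the amine nitrogen gives the first sized change at this place in this assay, a 1.5-fold higher number from compound 2 to compound 4 (0.19 log units; within the scatter). The two groups therefore cannot be told apart here, and a phenyl with two methyl groups keeps a measurable number just as the fluorinated one does. Compound 1, with its alkyl-bearing phenyl, remains only a limit: the limit of > 4000 nM in this assay, at which 1 of the 4 values shown sits.

On these data alone, whether any group at this nitrogen moves the number beyond the scatter stays open. A phenyl carrying a methoxy group or a carboxylic acid would test this further.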